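Adding one phenoxy group to compound 2

The source may report more compounds than this note shows. Statements on the series, on what has been measured and on what is new or still open speak of the compounds shown alone.

Among the compounds with values here, in a functional assay on MV4-11 cells (Homo sapiens) for antiproliferative activity, read by CCK-8 assay, with a stated time of 72 h (on this read-out higher numbers stand for weaker inhibition and lower numbers for stronger inhibition), compound 2 `Cn1cc(-c2cccc(C(C)(C)O)c2)c2cc(C(=O)NCc3ccc(C(=O)Nc4ccccc4N)cc3)[nH]c2c1=O` gives 2200 nM, the highest of the three numbers measured so far. Compound 4 `Cc1cc(F)cc(C)c1Oc1ccc(C(C)(C)O)cc1-c1cn(C)c(=O)c2[nH]c(C(=O)NCc3ccc(C(=O)Nc4ccccc4N)cc3)cc12` differs from it by one change: 4-fluoro-2,6-dimethylphenoxy in place of hydrogen on an aromatic carbon. Within the data shown here, the only measured step from compound 2 is to compound 3 `Cn1cc(-c2ccccc2F)c2cc(C(=O)NCc3ccc(C(=O)Nc4ccccc4N)cc3)[nH]c2c1=O`, which gives 230 nM. Among the measured compounds shown here, that step, a 9.6-fold lower number from compound 2 to compound 3 (0.98 log units; beyond the scatter), is a different change, so it shows only that this part of compound 2 can shift the number beyond the scatter. Compound 1 `Cc1cc(F)cc(C)c1Oc1ccc(C(C)(C)O)cc1-c1cn(C)c(=O)c2[nH]c(C(=O)NCc3ccc(C(=O)NO)cc3)cc12` carries the same 4-fluoro-2,6-dimethylphenoxy group and gives 440 nM, though it differs from compound 4 elsewhere. A lower number is therefore expected, an estimated 5.5-fold lower number from compound 2 to compound 4 (0.74 log units; beyond the scatter). For compound 4 the expected value is 400 nM, with an estimated range of 120 nM to 1300 nM.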

Compound 4, half-maximal inhibitory concentration: 240 nM
Estimate against measurement, compound 4: 1.7-fold (0.22 log units) above; low and high end bracket the measured number.
By their numbers in this assay, from the lowest: compounds 3, 4 and 1 (each within the scatter of the next); then compound 2.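

In this assay, placing 4-fluoro-2,6-dimethylphenoxy on this aromatic carbon, para to the 1-hydroxy-1-methylethyl group, lowers the number beyond the scatter (a 9.2-fold lower number from compound 2 to compound 4 (0.96 log units; beyond the scatter)), so this position accepts a group of this size. With that group present, 2-aminophenyl in place of hydroxy on the amide-type nitrogen leaves the two compounds within the scatter (a 1.8-fold lower number from compound 1 to compound 4 (0.26 log units; within the scatter)). No measured evidence here explains either step. As far as these compounds go, whether a much smaller group at this position, such as methoxy or an amine, would lower the number too remains open.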